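The source may report more compounds than this note shows. Statements on the series, on what has been measured and on what is new or still open speak of the compounds shown alone.

Compound 2 `CCOC(=O)c1c(-c2cccc(OCC)c2)[nH]c2cc(OC)ccc2c1=O` carries an ethoxy group on its pendant aromatic ring. In an ADME assay on HEK293 cells (Homo sapiens) for cytotoxicity, read by luminescence, with a stated time of 72 h (a higher number here means that more compound is needed for the effect, a lower number that less compound is needed), compound 2 reaches only a limit of the assay, > 22000 nM. Its close relative compound 1 `CCOC(=O)c1c(-c2cc(F)cc(OC)c2)[nH]c2cc(OC)ccc2c1=O` also gives only a limit in this assay, > 22000 nM. The step that the two limits leave unreadable from compound 1 to compound 2 cannot be read, since both values sit at the limit of > 22000 nM in this assay, at which 2 of the 2 values shown sit. Compound 3 `CCOC(=O)c1c(-c2cccc(Oc3ccccc3)c2)[nH]c2cc(OC)ccc2c1=O` differs from compound 2 by phenyl in place of ethyl on an oxygen on an aromatic ring. For the measured compounds named here, no measured step bears on this change, so the step of a number no higher from compound 2 to compound 3 (the limit leaves the size open) is expected to be none beyond the scatter. Compound 3 is therefore estimated at 22000 nM, within 12000 nM to 60000 nM.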

Compound 3, half-maximal effective concentration: > 22000 nM
Compound 3: no number, only a limit; the forecaster's own chance of this, stated with the estimate: 80%; the middle value lies on the limit itself.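

For the compounds shown here, compound 2 and compound 3 both give only a limit, so no step between them can be read: the limit of > 22000 nM in this assay, at which 3 of the 3 values shown sit.

Left open is how much of compound 1, compound 2 or compound 3 is needed for the effect in this assay and whether ethoxy to phenoxy changes that amount at all.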